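The source may hold more compounds than are shown below. What is called first, only, known or untested is meant among the compounds shown, and "the series" means these compounds.

Working notes on the aryl urea series. Within the data shown here, in a functional assay on CRL2813 cells (Homo sapiens) for cytotoxicity, read by sulforhodamine B assay, with a stated time of 5 days (a lower number here means a stronger inhibitor, a higher number a weaker inhibitor), compound 2 `O=C(Nc1ccc([N+](=O)[O-])cc1)N[C@H]1CC[C@H](Oc2ccc(F)cc2)CC1` gives 2300 nM, the lowest of the two numbers so far. Among the measured compounds shown here, its nearest neighbour is compound 1 `O=C(Nc1cccc(F)c1)N[C@H]1CC[C@H](Oc2ccc(F)cc2)CC1`, which in this assay gives 8300 nM; the single measured step, a 3.6-fold lower number from compound 1 to compound 2 (0.56 log units; beyond the scatter), is the only comparison available. Compound 3 `COc1cccc(NC(=O)N[C@H]2CC[C@H](Oc3ccc(F)cc3)CC2)c1` differs from compound 2 by 3-methoxyphenyl in place of 4-nitrophenyl on an amide-type nitrogen. For the measured compounds named here, no measured step touches a methoxy group, so the expectation rests only on the step from compound 1 to compound 2: that step brought in the 4-nitrophenyl and lowered the number, and compound 3 removes that group again in favour of another substituted phenyl, as in compound 1. The number for compound 3 is therefore expected to move back up, by a 2.6-fold higher number from compound 2 to compound 3 (0.42 log units; beyond the scatter), towards the range of compound 1. The estimate for compound 3 in this assay is 6000 nM, with a range of 2500 nM to 15000 nM.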

Compound 3, half-maximal inhibitory concentration: 14000 nM
Beside the measured number, compound 3's estimate is 2.3-fold (0.37 log units) below it, within the range that was stated.
By their numbers in this assay, from the lowest: compound 2; then compounds 1 and 3 (each within the scatter of the next).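

The change to 3-methoxyphenyl in place of 4-nitrophenyl on the amide-type nitrogen gives a 6.1-fold higher number from compound 2 to compound 3 (0.78 log units; beyond the scatter) in this assay and shows that the lower number of compound 2 is not shared by this other substituted phenyl. Methoxy in place of fluoro on an aromatic carbon gives a 1.7-fold higher number from compound 1 to compound 3 (0.23 log units; within the scatter) so compound 1 and compound 3 cannot be told apart, and compound 2 alone has the lowest number, with its steps to both beyond the scatter. Nothing available explains the difference between the 4-nitrophenyl and the other two aryl groups.

Compound 2 alone carries a 4-nitrophenyl, so the contributions of the nitro group and of its ring position cannot be separated. From the compounds shown here alone, how a nitrile, a trifluoromethyl or an amine on that phenyl would read in this assay remains open.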